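From Methoxy to Fluoro: The Step to Compound 4

The source may report more compounds than this note shows. Statements on the series, on what has been measured and on what is new or still open speak of the compounds shown alone.

In a functional assay on CNE-2 cells (Homo sapiens) for cytotoxicity, read by sulforhodamine B assay, with a stated time of 48 h (on this read-out higher numbers stand for weaker inhibition and lower numbers for stronger inhibition), compound 2 (`COc1cc(/C=C/C(=O)c2ccc(N)c(-c3ccc(F)cc3)c2)ccc1O`) gives 5750 nM as its reading. Compound 3 (`COc1ccc(/C=C/C(=O)c2ccc(N)c(-c3ccc(F)cc3)c2)cc1OC`) gives 3510 nM as its reading, and the two lie within the scatter of each other. Compound 1 (`COc1ccc(/C=C/C(=O)c2ccc(N)c(-c3ccc(F)cc3)c2)cc1O`) adds no number, its entry being "not determined" (no result reported) in this series. Going by the values given here, compound 2 therefore stands level with the only other compound that has a number.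

Compound 4 (`Nc1ccc(C(=O)/C=C/c2ccc(O)c(F)c2)cc1-c1ccc(F)cc1`) keeps the shared core and alters one group: fluoro in place of methoxy on an aromatic carbon in the change from 4-hydroxy-3-methoxyphenyl to 3-fluoro-4-hydroxyphenyl, with fluoro in place of methoxy on an aromatic carbon, ortho to a hydroxy group. Among the compounds with values here, no measured pair carries this exchange. Within the data shown here, the sole measured step is a different one, methyl in place of hydrogen on an oxygen on an aromatic ring, so it bears only loosely on the question. That step, leading to compound 3, is a 1.6-fold lower number from compound 2 to compound 3 (0.21 log units; within the scatter) and offers no sign of a large shift. No step beyond the scatter is therefore expected in this assay and the estimated step is a 1.2-fold lower number from compound 2 to compound 4 (0.06 log units; within the scatter) with no firm direction behind it. For compound 4 the estimated value is 5000 nM with an expected range from 2000 nM to 12500 nM on this read-out.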

Compound 4, half-maximal inhibitory concentration: 18100 nM
Beside the measured number, compound 4's estimate is 3.6-fold (0.56 log units) below it; measured number outside the range, above it.
By their numbers in this assay, from the lowest: compounds 3 and 2 (each within the scatter of the next); then compound 4.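

In this assay, fluoro in place of methoxy on the aromatic carbon ortho to a hydroxy group gives a 3.1-fold higher number from compound 2 to compound 4 (0.50 log units; beyond the scatter) and so weakens inhibition, the first change among these compounds to leave the scatter. The earlier step, methyl in place of hydrogen on an oxygen on an aromatic ring, gave a 1.6-fold lower number from compound 2 to compound 3 (0.21 log units; within the scatter) and stayed within the scatter, so it gave no sign that the reading of compound 2 could move this far with a single change to the 4-hydroxy-3-methoxyphenyl group. No measurement given here accounts for the loss seen with the 3-fluoro-4-hydroxyphenyl group, and the step stands as an observation without an explanation.

The compounds shown leave open whether the higher number follows from the loss of methoxy or from the arrival of fluoro, since a single exchange cannot separate the two. Nor do they show where hydrogen, chloro, ethoxy or an amine on the same carbon would fall relative to compound 2 and compound 4 in this assay on the shared core.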